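The compounds below may be only part of what the source reports. "The series", "measured", "known", "first", "only" and "open" are said of these compounds alone.

Of the compounds shown here, three have so far been tested in a functional assay on THP-1 cells (Homo sapiens) for cytotoxicity, read by MTT assay, with a stated time of 72 h; on this read-out lower numbers stand for stronger inhibition and higher numbers for weaker inhibition. For the measured compounds named here, compound 2 `COc1ccc(/C=C2\CC[C@H]3C(C)(C)CCC[C@]3(C)[C@H]2CCC(C)CC(=O)O)cc1OC` gives 106000 nM, the only true number among them. Compound 1 `C=C1CC[C@H]2C(C)(C)CCC[C@]2(C)[C@H]1CCC(C)CC(=O)OC` gives > 200000 nM, which is a limit of the assay and not a number. Compound 3 `CC(CC[C@H]1/C(=C/c2ccc(Br)cc2)CC[C@H]2C(C)(C)CCC[C@]12C)CC(=O)O` gives > 200000 nM, which is also a limit. Any reading of this small set has to reckon with the limit of > 200000 nM in this assay, at which 2 of the 3 values shown sit.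

The next compound, compound 4 `CC(CC[C@H]1/C(=C/c2ccc(I)cc2)CC[C@H]2C(C)(C)CCC[C@]12C)CC(=O)O`, departs from compound 2 at one place: 4-iodophenyl in place of 3,4-dimethoxyphenyl on a double-bonded chain carbon bound to a double-bonded ring carbon. Here, 4-iodophenyl takes the place of 3,4-dimethoxyphenyl on a double-bonded chain carbon bound to a double-bonded ring carbon. Going by the values given here, one measured step bears on this change. Compound 3 carries 4-bromophenyl at that same place, and the step is an at least 1.8-fold higher number from compound 2 to compound 3 (0.27 log units; that floor lies within the scatter). Going by these compounds, this is only a floor, so the true size of that step remains unknown. Among the compounds with values here, no measured step links compound 1 to compound 2, so it offers no guide here.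

In this assay, a modest move towards a higher number is therefore expected, and compound 4 may be reported only as a limit. The expected step is a 1.7-fold higher number from compound 2 to compound 4 (0.23 log units; within the scatter). For compound 4, the estimated value is 180000 nM, with an expected range from 80000 nM to 400000 nM.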

Compound 4, half-maximal inhibitory concentration: 33000 nM
The estimate for compound 4 lay 5.5-fold (0.74 log units) above the measured number; the measured number lies below the stated range.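

In this assay, this place on the double-bonded chain carbon proves able to move the number down as well as up: 4-iodophenyl in place of 3,4-dimethoxyphenyl gives a 3.2-fold lower number from compound 2 to compound 4 (0.51 log units; beyond the scatter), a direction the earlier bromo compound had not shown. Exchanging one halogen for another on the same aromatic carbon also matters here, since iodo in place of bromo gives an at least 6.0-fold lower number from compound 3 to compound 4 (0.78 log units; beyond the scatter), so 4-bromophenyl and 4-iodophenyl cannot be treated as interchangeable at this place. The true size of that halogen step stays unknown, and it can be read only as a floor because compound 3 stands at a limit rather than at a number: the limit of > 200000 nM in this assay, at which 2 of the 4 values shown sit.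

What the compounds shown leave open is whether iodo is a special case or part of a wider trend, which a 4-chlorophenyl or 4-fluorophenyl group at the same place would help to settle. They also do not tell which feature of the iodo group lies behind the lower number, or whether an aromatic ring bearing an amine at this place would follow the same course.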